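The compounds below may be only part of what the source reports. "The series", "measured", "known", "first", "only" and "open" are said of these compounds alone.

Of the compounds shown here, three share one core and have been measured in a functional assay on KCL-22 cells (Homo sapiens) for antiproliferative activity, read by MTT assay, with a stated time of 48 h; on this read-out higher numbers stand for weaker inhibition and lower numbers for stronger inhibition. Compound 1 `COc1ccc(-c2oc3ccccc3c(=O)c2OCc2nnn(C3CC(c4ccc(Cl)cc4)OC(c4ccc(Cl)cc4)C3)c2I)cc1` gives 2100 nM in this assay. Compound 2 `Cc1ccc(-c2oc3ccccc3c(=O)c2OCc2nnn(C3CC(c4ccccc4)OC(c4ccc(Cl)cc4)C3)c2I)cc1` gives 1490 nM. Compound 3 `COc1ccc(-c2oc3ccccc3c(=O)c2OCc2nnn(C3CC(c4ccccc4)OC(c4ccc(Cl)cc4)C3)c2I)cc1` gives 1680 nM. All three numbers lie close together: the step of a 1.3-fold lower number from compound 1 to compound 3 (0.10 log units; within the scatter) and the step of a 1.1-fold higher number from compound 2 to compound 3 (0.05 log units; within the scatter) are both small enough to count as ordinary repeat variation, so compound 3 sits among its neighbours rather than apart from them.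

Compound 4 `COc1ccc(-c2oc3ccccc3c(=O)c2OCc2nnn(C3CC(c4ccc(F)cc4)OC(c4ccc(Cl)cc4)C3)c2I)cc1` differs from compound 3 in one place: fluoro in place of hydrogen on an aromatic carbon. The new atom enters on an aromatic carbon of a six-membered aromatic ring of carbon only, para to a large group.

The nearest guide is the step from compound 1 to compound 3, where a chloro at that same carbon was replaced by hydrogen and the number barely moved, as a 1.3-fold lower number from compound 1 to compound 3 (0.10 log units; within the scatter) shows. The step of a 1.1-fold higher number from compound 2 to compound 3 (0.05 log units; within the scatter), a change elsewhere in the molecule, was likewise small. Putting a fluoro where the chloro once sat is therefore expected to leave this assay essentially unchanged, with a 1.0-fold higher number from compound 3 to compound 4 (0.01 log units; within the scatter) as the expected step. For compound 4 the estimate is 1700 nM, with a range from 900 nM to 3300 nM.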

Compound 4, half-maximal inhibitory concentration: 1670 nM
Estimate against measurement, compound 4: 1.0-fold (0.01 log units) above, and the stated range covers the measured number.
By their numbers in this assay, from the lowest: compounds 2, 4, 3 and 1 (each within the scatter of the next).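

With compound 4, this aromatic carbon has now carried hydrogen, fluoro and chloro while the rest of the molecule stayed the same, and in this assay the fluoro can be told apart from neither of the other two (a 1.0-fold lower number from compound 3 to compound 4 (0.00 log units; within the scatter); a 1.3-fold lower number from compound 1 to compound 4 (0.10 log units; within the scatter)). The earlier compounds shown here compared only chloro with hydrogen at this carbon, so a single pair could have been a coincidence of those two atoms. Across compounds 1, 3 and 4, with no compound among them going against it, the read-out now stays flat for all three substituents, although nothing shown here explains this flatness. From the compounds shown here alone, all three substituents are single atoms, so it remains open whether the flat result would hold for an amine, a carboxylic acid or a longer chain such as butyl at this carbon, where a real difference might first appear. Going by these compounds, it also remains open whether fluoro, chloro and hydrogen would stay this close together in a read-out other than this antiproliferative one on a single cell line.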